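This account rests on a few compounds, and the source may have more. Where it says the series, first, only, none or still open, it means among the compounds named here.

Measured so far:
compound 1 `Cc1cc(/C=C/c2ccc(O)cc2)[nH]n1` — 32900 nM
compound 2 `COc1ccc(/C=C/c2cc(C)n[nH]2)cc1` — 8400 nM
compound 3 `COc1ccc(/C=C/c2cc(C)no2)cc1` — 76400 nM

In a functional assay on S1 cells (Homo sapiens) for cytotoxicity, read by MTT assay, with a stated time of 72 h (on this read-out lower numbers stand for stronger inhibition and higher numbers for weaker inhibition), compound 2 gives the lowest number of the three, and compound 3 the highest; the gaps from compound 3 to compound 1 and to compound 2 both lie beyond the scatter. How the core of compound 2 differs from the core of compound 3 is not broken down here.

One change is seen twice in this set. From compound 2 to compound 1 it reads hydrogen in place of methyl on an oxygen on an aromatic ring and it gave a 3.9-fold higher number from compound 2 to compound 1 (0.59 log units; beyond the scatter). From compound 3 to compound 4 `Cc1cc(/C=C/c2ccc(O)cc2)on1` the change reads (hydrogen in place of methyl on an oxygen on an aromatic ring); the place lines are the same word for word, so it is the same change on a different core.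

For compound 4 a step of about the size a 3.3-fold higher number from compound 3 to compound 4 (0.51 log units; beyond the scatter) is expected in this assay, resting on the single earlier occurrence, the step of a 3.9-fold higher number from compound 2 to compound 1 (0.59 log units; beyond the scatter). Among the measured compounds shown here, only one such step is known, and the core differs. The range is therefore kept wide. Compound 4 is estimated at 250000 nM, expected between 80000 nM and 800000 nM.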

Compound 4, half-maximal inhibitory concentration: 44200 nM
Beside the measured number, compound 4's estimate is 5.7-fold (0.75 log units) above it; measured number below the stated range.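

In this assay the change from methoxy to hydroxy reads a 1.7-fold lower number from compound 3 to compound 4 (0.24 log units; within the scatter) and so stays within the scatter on this core. Set beside the earlier step, the same change does not carry over as a fixed step from one core to the other: the same change on two cores in this assay, a 3.9-fold higher number (0.59 log units; beyond the scatter) from compound 2 to compound 1 and a 1.7-fold lower number (0.24 log units; within the scatter) from compound 3 to compound 4, 6.8-fold (0.83 log units) apart, beyond the scatter of two such steps

Among the compounds shown here, only two pairs stand behind this comparison, so it shows that in these compounds the size of the step differs with the core, but it does not show which feature of the cores goes with that difference or what the change would give on a further core.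

Left open is how an amine or a longer chain such as ethoxy would read in place of methoxy on each of the two cores. Also open, on these data alone, is whether a third core would fall closer to the step seen on the core of compound 1 or to the step seen on the core of compound 3.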